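Chloro in place of nitro on an aromatic carbon

The source may hold more compounds than are shown below. What is called first, only, known or untested is meant among the compounds shown, and "the series" means these compounds.

Of the compounds shown here, two have been measured so far. In a functional assay on SMMC-7721 cells (Homo sapiens) for cytotoxicity, read by MTT assay, with a stated time of 24 h (on this read-out higher numbers stand for weaker inhibition and lower numbers for stronger inhibition), compound 1 (`O=C1/C(=C/c2cccnc2)CN(S(=O)(=O)c2ccc(Cl)cc2)C/C1=C\c1ccccc1F`) gives 16100 nM, and compound 2 (`O=C1/C(=C/c2cccnc2)CN(S(=O)(=O)c2ccc([N+](=O)[O-])cc2)C/C1=C\c1ccccc1C(F)(F)F`) gives 15900 nM. These two values lie within the usual scatter of each other, so compound 2 stands level with compound 1 and neither can be ranked ahead.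

The next compound to be read is compound 3 (`O=C1/C(=C/c2cccnc2)CN(S(=O)(=O)c2ccc(Cl)cc2)C/C1=C\c1ccccc1C(F)(F)F`). It departs from compound 2 in one place: chloro in place of nitro on an aromatic carbon. In words, chloro replaces nitro on an aromatic carbon, para to a large group, turning (4-nitrophenyl)sulfonyl into (4-chlorophenyl)sulfonyl.

Among the measured compounds shown here, no step between measured compounds is available to size this change directly, and two compounds show no trend. The expectation therefore rests only on the narrow spread of compound 1 at 16100 nM and compound 2 at 15900 nM. No shift beyond the scatter is expected in this assay, in either direction. The expected 1.1-fold lower number from compound 2 to compound 3 (0.03 log units; within the scatter) is small. For compound 3 the estimated value is 15000 nM, with an expected range of 7000 nM to 32000 nM.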

Compound 3, half-maximal inhibitory concentration: 4880 nM
Beside the measured number, compound 3's estimate is 3.1-fold (0.49 log units) above it; measured number below the stated range.
By their numbers in this assay, from the lowest: compound 3; then compounds 2 and 1 (each within the scatter of the next).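

With the trifluoromethyl group held constant, in this assay chloro in place of nitro on an aromatic carbon gives a 3.3-fold lower number from compound 2 to compound 3 (0.51 log units; beyond the scatter) and so shows that this position, on the ring of the sulfonyl group, bears on the read-out; the two earlier compounds differ in two places at once and could not show this. With the (4-chlorophenyl)sulfonyl group held constant, trifluoromethyl in place of fluoro on an aromatic carbon gives a 3.3-fold lower number from compound 1 to compound 3 (0.52 log units; beyond the scatter) and so shows that the second position bears on the read-out as well, with each single change from compound 3 reaching beyond the scatter. Nothing at hand bears on why either change goes with a lower number.

From the compounds shown here alone, both steps end at compound 3, so it remains open whether either holds when the other position carries a different group, as with nitro on the sulfonyl ring together with fluoro on the other ring. Also open, going by these compounds, is how the read-out responds to other groups in place of chloro, such as an amine or a methoxy group, on the shared core.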